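A few compounds are considered here, and "the series" means these few. Any claim that something is new, unique, unknown or untested is made for them only; others in the source may bear on it.

Measured so far in a functional assay on HCT-116 cells (Homo sapiens) for cytotoxicity, read by MTT assay, with a stated time of 72 h; on this read-out lower numbers stand for stronger inhibition and higher numbers for weaker inhibition:

Compound 1 `Nc1ccc(Nc2c(C(=O)NCc3ccc(F)cc3)nc(Br)c3cccnc23)cc1`: 10000 nM
Compound 2 `CS(=O)(=O)NCCCN(c1nc(C(=O)NCc2ccc(F)cc2)c(O)c2ncccc12)S(C)(=O)=O`: 15000 nM
Compound 3 `NCCCNc1c(C(=O)NCc2ccc(F)cc2)ncc2cccnc12`: > 10000 nM

In this assay compound 1 gives 10000 nM, one of the two numbers available; compound 2 gives 15000 nM, which sits within the usual scatter of the value of compound 1, so the two cannot be told apart. For compound 3 this assay reports only a limit, > 10000 nM, and no number; this is the limit of > 10000 nM in this assay, at which 1 of the 3 values shown sits. Within the data shown here, all three compounds thus sit in a weak range, and no step between measured compounds that differ in one place is available.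

Compound 4 `Cc1ccc(S(=O)(=O)Oc2c(C(=O)NCc3ccc(F)cc3)nc(Br)c3cccnc23)cc1` is not yet measured. It differs from compound 1 as follows: ((4-methylphenyl)sulfonyl)oxy in place of (4-aminophenyl)amino on an aromatic carbon. The measured compounds do not show what such a change does, so the expectation for the step from compound 1 to compound 4 is none beyond the scatter, with a real chance that only a limit is reported. Compound 4 is therefore estimated at 12000 nM, between 4000 nM and 40000 nM, which corresponds to an expected step of a 1.2-fold higher number from compound 1 to compound 4 (0.08 log units; within the scatter).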

Compound 4, half-maximal inhibitory concentration: > 20000 nM
Compound 4 ended at the assay's limit; the forecaster's own chance of this, stated with the estimate: 40%; at least 1.6-fold (0.22 log units) between middle value and limit.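

In this assay compound 4 returns no number, only a limit: the limit of > 20000 nM in this assay, at which 1 of the 4 values shown sits.

With ((4-methylphenyl)sulfonyl)oxy in place of (4-aminophenyl)amino on this aromatic carbon, para to a bromo group, the series now has its first step at this position: an at least 2.0-fold higher number from compound 1 to compound 4 (0.30 log units; that floor lies within the scatter). That step has only a floor, so it gives no measured size for the change, and this exchange yields no value stronger than that of compound 1.

On these data alone, whether any group on this carbon can bring the series out of its weak range stays open; a morpholine or a carboxylic acid here, with the bromo group kept, would each differ from compound 1 in one place. As far as these compounds go, how far the true value of compound 4 lies beyond its limit also remains unknown.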